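The source may hold more compounds than are shown below. What is called first, only, known or untested is meant among the compounds shown, and "the series" means these compounds.

Working notes on the series.

Two compounds carry measured numbers in a functional assay on A549 cells (Homo sapiens) for cytotoxicity, read by colorimetric assay and MTT assay, with a stated time of 3 days, tested at 20 uM; on this read-out higher numbers stand for a weaker effect at the one concentration tested and lower numbers for a stronger effect. Compound 1 `COc1ccc(-c2nc(-c3ccccc3)c(-c3ccc4c(c3)NC(=O)CO4)[nH]2)cc1` gives 38.1% in this assay. Compound 2 `O=C1COc2ccc(-c3[nH]c(-c4ccc(C(F)(F)F)cc4)nc3-c3ccccc3)cc2N1` gives 21.7% in this assay. Among the compounds with values here, the single step between them, a number 16.4 percentage points lower from compound 1 to compound 2 (beyond the scatter), is the only measured change available, and it concerns a substituent on the pendant aryl ring of the shared core. On the numbers shown, compound 2 stands lowest of the two, with compound 1 as its nearest neighbour a distance beyond the scatter above it.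

Compound 3 `O=C1COc2ccc(-c3[nH]c(-c4ccc(Cl)cc4Cl)nc3-c3ccccc3)cc2N1` is not yet measured. Its difference from compound 2 is 2,4-dichlorophenyl in place of 4-(trifluoromethyl)phenyl on an aromatic carbon. Within the data shown here, no measured step touches a dichloro pattern; the one step that exists swaps a methoxy for a trifluoromethyl at the same ring and was modest in size. Nothing therefore argues for a step beyond the scatter from compound 2 to compound 3 in this assay, in either direction, and the expected step is a number 0.3 percentage points higher from compound 2 to compound 3 (within the scatter), essentially flat. Compound 3 is thus estimated at 22% in this assay, with a range from 8% to 40%.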

Compound 3, a percentage reported as activity, at one concentration (the size of the read-out at that concentration, not a potency): 68.3%
Estimate against measurement, compound 3: 46.3 percentage points below, and the stated range ends below it.
By their numbers in this assay, from the lowest: compound 2; then compound 1; then compound 3.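

Working notes, continued. In this assay, within the data shown here, the aromatic carbon between two ring nitrogen atoms proves far more sensitive to the choice of aryl group than the one earlier step suggested: a number 46.6 percentage points higher from compound 2 to compound 3 (beyond the scatter) when 2,4-dichlorophenyl replaces 4-(trifluoromethyl)phenyl. The same group also separates clearly from 4-methoxyphenyl, with a number 30.2 percentage points higher from compound 1 to compound 3 (beyond the scatter) for that change, so among these three compounds, compound 3 shows the weakest effect at the one concentration tested, and a halogen-bearing phenyl group at this carbon does not by itself secure the stronger effect seen with compound 2. No supporting data bear on why this aryl change shifts the read-out so sharply.

The compounds shown leave open whether the weaker effect requires both chlorines of the 2,4-dichlorophenyl group, as a phenyl group with a single chlorine would test. Also open, as far as these compounds go, is how this carbon would respond to a phenyl group carrying an amine or a carboxylic acid, and whether these differences would persist across a range of concentrations.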